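The source may hold more compounds than are shown below. What is called first, only, known or untested is meant among the compounds shown, and "the series" means these compounds.

Compound 2 `CCOC(=O)C1CCCN(Cc2cn(C3CCCCC3OC(=O)COc3ccccc3)nn2)C1` and compound 1 `CN(Cc1cn(C2CCCCC2OC(=O)COc2ccccc2)nn1)CC1CCCCC1` share a core and differ only in the group attached to a saturated chain carbon bound to an aromatic carbon. In an assay on nucleic acid for inhibition of Nucleic Acid, read by fluorescence, tested at 100 uM (on this read-out lower numbers stand for less inhibition and higher numbers for more inhibition at the one concentration tested (going by the name of the read-out)), compound 1 gives 37%, and compound 2 gives 21%, the lower of the two numbers; the change is a number 16 percentage points lower from compound 1 to compound 2 (beyond the scatter). Compound 3 `CCOC(=O)C1CCCN(Cc2cn(C3CCCCC3O)nn2)C1` arises from compound 2 by hydrogen in place of (phenoxymethyl)carbonyl on an oxygen on a saturated carbon. Among the compounds with values here, the one measured step concerns a different part of the molecule and so does not speak to this change; no measured pair shows what the loss of the (phenoxymethyl)carbonyl group does. With nothing to lean on, the expectation for compound 3 is kept close to the low number of compound 2, leaning somewhat lower, as an expected step of a number 6 percentage points lower from compound 2 to compound 3 (within the scatter). Compound 3 is therefore estimated at 15%, within a range from 0% to 35%.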

Compound 3, a percentage reported as inhibition, at one concentration (the size of the read-out at that concentration, not a potency): 16%
Estimate against measurement, compound 3: 1 percentage points below; the measured number falls inside the stated range.
By their numbers in this assay, from the lowest: compounds 3 and 2 (each within the scatter of the next); then compound 1.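

In this assay, the change from ((phenoxymethyl)carbonyl)oxy to hydroxy, on an oxygen on a saturated carbon, comes out as a number 5 percentage points lower from compound 2 to compound 3 (within the scatter), so this read-out does not separate the two compounds. Within the data shown here, the earlier step concerned a different part of the molecule, and this is the first reading at this oxygen: the whole (phenoxymethyl)carbonyl group, aromatic ring included, can leave without a change beyond the scatter. Nothing available explains this result.

The compounds shown leave open whether hydroxy would compare the same way with (cyclohexylmethyl)(methyl)amino in place of 3-(ethoxycarbonyl)piperidin-1-yl. They also leave open what an acetyl group or a methyl group on this oxygen would do, or a carboxylic acid in place of the ethyl ester.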